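Replacing cyclopropylcarbonyl in the series: half-life notes

The source may hold more compounds than are shown below. What is called first, only, known or untested is meant among the compounds shown, and "the series" means these compounds.

Of the compounds shown here, two have been measured so far in an ADME assay on the whole organism for pharmacokinetics, with Rattus norvegicus as the target (a lower number here means that the compound disappears faster, a higher number that the compound lasts longer), for comparison. Compound 1 `Cc1cc(C)c(NC(=O)c2sccc2S(=O)(=O)Nc2onc(C)c2Cl)c(C(=O)C2CC2)c1` gives 5.4 h and stands highest of the two numbers. Compound 2 `CC(=O)c1c(C)c(C)cc(C)c1NC(=O)c1sccc1S(=O)(=O)Nc1onc(C)c1Cl` gives 1.68 h and lies lower than compound 1 by more than the usual scatter.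

Compound 3 `C/C(=N\O)c1cc(C)cc(C)c1NC(=O)c1sccc1S(=O)(=O)Nc1onc(C)c1Cl` differs from compound 1 in one place, on an aromatic carbon ortho to a large group and meta to two methyl groups (a group of 4 heavy atoms (2 carbon, 1 nitrogen, 1 oxygen; no ring) in place of a group of 5 heavy atoms (4 carbon, 1 oxygen; one three-membered non-aromatic ring of carbon only), on an aromatic carbon). For the measured compounds named here, no measured step covers this change, and compound 1 and compound 2 differ in more than one place. Compound 2 at 1.68 h is the only lower reference. A modest decrease is expected (a 1.8-fold lower number from compound 1 to compound 3 (0.26 log units; within the scatter)), not clearly beyond the scatter. For compound 3 the estimate is 3 h with 1.2 h to 7 h as the expected range.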

Compound 3, half-life: 5.2 h
For compound 3 the middle estimate is 1.7-fold (0.24 log units) below the measured one, and the stated range covers the measured number.
By their numbers in this assay, from the lowest: compound 2; then compounds 3 and 1 (each within the scatter of the next).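

In this assay, for the compounds shown here, replacing cyclopropylcarbonyl with the ring-free group of 4 heavy atoms gives a 1.0-fold lower number from compound 1 to compound 3 (0.02 log units; within the scatter), the first step that isolates this position, on an aromatic carbon ortho to a large group and meta to two methyl groups. Neither the three-membered ring nor the cyclopropylcarbonyl group as a whole is therefore required here for a half-life of this size, and the entering group's hydrogen-bond donor brings no step beyond the scatter. No supporting data explain this result.

The compounds shown leave open whether the half-life also holds with an amine, a carboxylic acid or a longer chain at this position. They also leave open whether the same replacement would behave alike on the substitution pattern of compound 2.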